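From Furan to Methylphenyl: One Change, One Expectation

The compounds below may be only part of what the source reports. "The series", "measured", "known", "first", "only" and "open" are said of these compounds alone.

In a functional assay on SJ-G2 cells (Homo sapiens) for inhibition, read by MTT assay, with a stated time of 72 h (on this read-out higher numbers stand for weaker inhibition of growth and lower numbers for stronger inhibition of growth), the measured compounds stand as follows:
Compound 1, `COc1ccc(CNC(=O)/C(C#N)=C/c2ccco2)cc1`, gives 31000 nM.
Compound 2, `N#C/C(=C\c1ccco1)C(=O)NCc1ccc(Cl)c(Cl)c1`, gives > 50000 nM, which is a limit of the assay and not a number.

Among the compounds with values here, compound 1 holds the only real number in this set; the other result is the limit of > 50000 nM in this assay, at which 1 of the 2 values shown sits. Compound 3, `COc1ccc(CNC(=O)/C(C#N)=C/c2ccc(C)cc2)cc1`, differs from compound 1 in a single place: 4-methylphenyl in place of furan-2-yl on a double-bonded chain carbon bound to a double-bonded chain carbon. Within the data shown here, no pair of measured compounds differing in one place has been compared in this assay, so nothing here tells how such a swap shifts growth inhibition. The shared core is kept, and the change trades one aromatic ring for another of a different size. With nothing to point either way, the step from compound 1 to compound 3 is expected to stay within the scatter, as a 1.0-fold lower number from compound 1 to compound 3 (0.01 log units; within the scatter). Compound 3 is therefore estimated at 30000 nM, with a range from 8000 nM to 100000 nM.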

Compound 3, concentration for 50% growth inhibition: 39000 nM
Compound 3: middle estimate off by 1.3-fold (0.11 log units), on the low side; measured number inside the range.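

In this assay, putting 4-methylphenyl in place of furan-2-yl on a double-bonded chain carbon bound to a double-bonded chain carbon gives a 1.3-fold higher number from compound 1 to compound 3 (0.10 log units; within the scatter). Within the data shown here, this is the first comparison in the set between two compounds that differ in one place, and it shows that a six-membered ring of carbon only can stand here with no shift that can be told from the scatter, even though the entering group has more heavy atoms and no hydrogen-bond acceptor. One result in the set is not a number but a limit of the assay: the limit of > 50000 nM in this assay, at which 1 of the 3 values shown sits.

As far as these compounds go, whether a group of another kind in this place, such as an amine, a carboxylic acid or a longer chain, would move the number beyond the scatter stays open. Also open, from the compounds shown here alone, is whether the same swap would give a similarly small step on a core other than that of compound 1.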